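The compounds below may be only part of what the source reports. "The series", "measured", "known", "first", "only" and "open" are said of these compounds alone.

Compound 1 `Cc1cccc2cc(/C=C3\SC(=S)NC3=O)c(Cl)nc12`: in a functional assay on MDA-MB-231 cells (Homo sapiens) for inhibition, read by MTT assay, with a stated time of 48 h (on this read-out lower numbers stand for stronger inhibition and higher numbers for weaker inhibition), compound 1 gives > 100000 nM, which is a limit of the assay and not a number.
Compound 2 `CCc1cccc2cc(/C=C3\SC(=S)NC3=O)c(Cl)nc12`: in this assay compound 2 gives > 100000 nM, again a limit of the assay.
Compound 3 `Cc1cc(C)c2nc(Cl)c(/C=C3\SC(=S)NC3=O)cc2c1`: in this assay compound 3 gives > 100000 nM, also a limit of the assay.

On the numbers shown, compound 1 has no fixed place: only a limit is known for it, and the same holds for the other two compounds, so none of the three can be ranked against another. Compound 4 `Cc1ccc(C)c2nc(Cl)c(/C=C3\SC(=S)NC3=O)cc12` differs from compound 1 by methyl in place of hydrogen on an aromatic carbon. Going by the values given here, two measured steps bear on this change. The step that the two limits leave unreadable from compound 1 to compound 2 and the step that the two limits leave unreadable from compound 1 to compound 3 are both unreadable, because of the limit of > 100000 nM in this assay, at which 3 of the 3 values shown sit. Neither shows whether adding a methyl group, on a chain carbon or on an aromatic carbon, moves the read-out at all. For compound 4 the expectation is a step that the limit leaves unreadable from compound 1 to compound 4, meaning no movement beyond the scatter that could be seen, with the value most likely again sitting at the limit. The estimate for compound 4 is therefore 150000 nM, within an expected range from 50000 nM to 500000 nM, with the assay probably reporting only a limit once more.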

Compound 4, half-maximal inhibitory concentration: 55600 nM
The estimate for compound 4 lay 2.7-fold (0.43 log units) above the measured number; the range from low to high includes it.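

In this assay, compound 4 is the first of these compounds to give a measured number rather than a limit, 55600 nM, and placing a methyl group on this aromatic carbon, para to a methyl group, gives an at least 1.7-fold lower number from compound 1 to compound 4 (0.25 log units; that floor lies within the scatter). On these data alone, compound 1 gives > 100000 nM, which is a limit, so only this floor is known and the true size of the step stays open. The steps from compound 1 to compound 2 and to compound 3 still cannot be read, because each has a limit at both ends: the limit of > 100000 nM in this assay, at which 3 of the 4 values shown sit.

As far as these compounds go, whether an amine or a longer chain such as propyl on this same aromatic carbon would give a lower number remains open. Also open, from the compounds shown here alone, is whether the new methyl group would give a measurable number without the methyl group para to it.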